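Chloro to methyl exchange on the aryl-bearing compound

The source may hold more compounds than are shown below. What is called first, only, known or untested is meant among the compounds shown, and "the series" means these compounds.

So far, three compounds of the shared core carry numbers in a functional assay on SF-268 cells (Homo sapiens) for antiproliferative activity, read by MTT assay, with a stated time of 96 h; on this read-out lower numbers stand for stronger inhibition and higher numbers for weaker inhibition. Compound 1 `O=C1NNC(=O)C2(CSC3=C2C(=O)c2ncccc2C3=O)N1` gives 4820 nM. Compound 2 `O=C1NC(=O)C2(CSC3=C2C(=O)c2ncccc2C3=O)N1` gives 3100 nM. Compound 3 `O=C1C2=C(C(=O)c3ncccc31)C1(CS2)NC(=O)N(c2ccc(Cl)cc2)C1=O` gives 580 nM, the lowest of the three; the nearest is compound 2 and the furthest compound 1. Going by the values given here, the only single-site change measured so far is a 5.3-fold lower number from compound 2 to compound 3 (0.73 log units; beyond the scatter), placing 4-chlorophenyl in place of hydrogen on an amide-type nitrogen in a ring.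

Compound 4 `Cc1ccc(N2C(=O)NC3(CSC4=C3C(=O)c3ncccc3C4=O)C2=O)cc1` keeps that aryl group and alters only its substituent: methyl in place of chloro on an aromatic carbon. Among the compounds with values here, no measured pair varies what sits on this aromatic carbon, so the one step in hand speaks to the presence of the aryl group, not to the group on its ring. With compound 3 and compound 4 carrying the same kind of substituted phenyl at the same place, no step beyond the usual scatter is expected in this assay in either direction. Compound 4 is therefore estimated at 700 nM (range 300 nM to 1600 nM), a step of a 1.2-fold higher number from compound 3 to compound 4 (0.08 log units; within the scatter), which is expected to stay within the scatter.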

Compound 4, half-maximal inhibitory concentration: 660 nM
Estimate against measurement, compound 4: 1.1-fold (0.03 log units) above; the range from low to high includes it.
By their numbers in this assay, from the lowest: compounds 3 and 4 (each within the scatter of the next); then compounds 2 and 1 (each within the scatter of the next).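

In this assay, going by these compounds alone, the first pair to vary the group on this aromatic carbon gives a 1.1-fold higher number from compound 3 to compound 4 (0.06 log units; within the scatter) and so leaves chloro and methyl unseparated. Placing an aryl group on the ring nitrogen gives a 4.7-fold lower number from compound 2 to compound 4 (0.67 log units; beyond the scatter) with 4-methylphenyl as well as the step seen with 4-chlorophenyl, so the lower number does not rest on chlorine alone. No evidence is at hand on why these two groups read alike.

On these data alone, whether a methoxy group, an amine or a carboxylic acid on this aromatic carbon would keep the number in the same range stays open. Also open, as far as these compounds go, is how plain phenyl, with hydrogen on that carbon, would read, which would show whether any substituent is needed there at all.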